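Working notes: compound 3 to compound 4

A few compounds are considered here, and "the series" means these few. Any claim that something is new, unique, unknown or untested is made for them only; others in the source may bear on it.

Values in an ADME assay on Vero cells (Chlorocebus sabaeus) for cytotoxicity, read by neutral red uptake, with a stated time of 3 days; on this read-out lower numbers stand for higher toxicity in this test and higher numbers for lower toxicity in this test:
- compound 1 `CCN(CC)CCNC(=O)c1cc(C2CC2)nc2c1cnn2C(C)C`: 53600 nM
- compound 2 `CCn1ncc2c(C(=O)NCCN(C)C)cc(C3CC3)nc21`: > 300000 nM (a limit of the assay, not a number)
- compound 3 `CCCn1ncc2c(C(=O)NCCN(C)C)cc(C3CC3)nc21`: 111000 nM

Of the two actual numbers in this assay, the higher belongs to compound 3 at 111000 nM. Compound 1 lies lower, beyond the scatter, while compound 2 carries only a limit.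

Compound 4 `CCC(C)n1ncc2c(C(=O)NCCN(C)C)cc(C3CC3)nc21` has not yet been measured. Its structure differs from compound 3 by methyl in place of hydrogen on a saturated chain carbon bound to an aromatic nitrogen and a saturated chain carbon, which reads propyl to sec-butyl.

Going by the values given here, one measured step bears on this change: an at least 2.7-fold lower number from compound 2 to compound 3 (0.43 log units; beyond the scatter). That step is also methyl in place of hydrogen, but two bonds along the chain from an aromatic nitrogen, and it starts from a limit, so its true size is open. A further drop of comparable size is therefore expected in this assay, though the range also allows little change.

The estimated change is a 1.7-fold lower number from compound 3 to compound 4 (0.23 log units; within the scatter). For compound 4 the expected value is 65000 nM, with an estimated range of 30000 nM to 130000 nM.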

Compound 4, half-maximal cytotoxic concentration: 101000 nM
Estimate against measurement, compound 4: 1.6-fold (0.19 log units) below; the range from low to high includes it.
By their numbers in this assay, from the lowest: compounds 1, 4 and 3 (each within the scatter of the next, the first and the last beyond it). At a limit, above all of these: compound 2.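

In this assay, the methyl on the saturated chain carbon bound to an aromatic nitrogen and a saturated chain carbon gives a 1.1-fold lower number from compound 3 to compound 4 (0.04 log units; within the scatter), so propyl to sec-butyl leaves the number within the scatter, whereas the methyl two bonds along the chain gave an at least 2.7-fold lower number from compound 2 to compound 3 (0.43 log units; beyond the scatter). Going by these compounds alone, with ethyl in place of hydrogen on this same carbon, the result is an at least 2.9-fold lower number from compound 2 to compound 4 (0.47 log units; beyond the scatter), so the one step beyond the scatter at this carbon also starts from a limit. Compound 2 carries a limit and not a number, which leaves the true size of that step open: the limit of > 300000 nM in this assay, at which 1 of the 4 values shown sits.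

On these data alone, whether a longer chain or an amine on this carbon would stay level with sec-butyl remains open. The compounds shown also give no actual number for compound 2.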